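From methyl to (ethoxycarbonyl)methyl on compound 2

This account rests on a few compounds, and the source may have more. Where it says the series, first, only, none or still open, it means among the compounds named here.

In a functional assay on U-87MG ATCC cells for cytotoxicity against U-87 MG (Homo sapiens), read by MTT assay, with a stated time of 48 h (a lower number here means a stronger inhibitor, a higher number a weaker inhibitor), compound 1 `CCOC(=O)C[n+]1cccc(O)c1` gives > 200000 nM, which is a limit of the assay and not a number. For the measured compounds named here, compound 2 `C[n+]1cccc(OP(=O)([O-])OC[C@H]2O[C@@H](n3cc(F)c(=O)[nH]c3=O)C[C@@H]2OC(=O)c2ccccc2)c1` gives 590 nM, the only true number so far, so it has no measured neighbour to be compared with step by step.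

Compound 3 `CCOC(=O)C[n+]1cccc(OP(=O)([O-])OC[C@H]2O[C@@H](n3cc(F)c(=O)[nH]c3=O)C[C@@H]2OC(=O)c2ccccc2)c1` has not yet been measured. It differs from compound 2 in one place, with ethoxycarbonyl in place of hydrogen on a saturated chain carbon bound to an aromatic nitrogen. The same change can be read as methyl to (ethoxycarbonyl)methyl.

Going by the values given here, no measured step shows what this change does in this assay. Among the compounds with values here, because compound 2 gives 590 nM and only one place changes, a modest shift toward weaker inhibition is expected. The estimated step runs a 1.5-fold higher number from compound 2 to compound 3 (0.18 log units; within the scatter). Compound 3 is expected at 900 nM, with an estimated range from 250 nM to 4000 nM.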

Compound 3, half-maximal inhibitory concentration: 580 nM
The estimate for compound 3 lay 1.6-fold (0.19 log units) above the measured number; measured number inside the range.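

Adding ethoxycarbonyl on the saturated chain carbon bound to an aromatic nitrogen gives the first readable step at this place in this assay: a 1.0-fold lower number from compound 2 to compound 3 (0.01 log units; within the scatter). Compound 2 and compound 3 therefore cannot be told apart here, so this place accepts a group of 5 heavy atoms, read as methyl to (ethoxycarbonyl)methyl, without a change beyond the usual scatter. Compound 1 also carries (ethoxycarbonyl)methyl, but its entry is a limit of the assay and not a number, and it differs from compound 3 in more than one place, so no step can be read there: the limit of > 200000 nM in this assay, at which 1 of the 3 values shown sits.

Only this one replacement is shown at this place, so one flat step cannot show how far the tolerance extends. A carboxylic acid in place of the ethyl ester, an amine or a longer chain on the same carbon could give a different result.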